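The source may hold more compounds than are shown below. What is called first, only, known or untested is meant among the compounds shown, and "the series" means these compounds.

Of the two numbers measured in a functional assay on the whole organism (Abdomen, strain Swiss) for inhibition, with Mus musculus as the target, with stated times of 30 min, 10 min and 5 min, at a dose of 10 mg/kg by the oral route (on this read-out higher numbers stand for a stronger effect at the one dose given and lower numbers for a weaker effect), compound 2 `O=c1occ(-c2ccccc2)n1CCCN1CCN(c2cccc(Cl)c2)CC1` holds the lowest, giving 7%, while compound 1 `O=c1occ(-c2ccccc2)n1CCCN1CCN(c2ccc(F)cc2)CC1` gives 14%; the step between them, a number 7 percentage points lower from compound 1 to compound 2 (within the scatter), stays within the scatter. Compound 3 `COc1cccc(N2CCN(CCCn3c(-c4ccccc4)coc3=O)CC2)c1` differs from compound 2 by methoxy in place of chloro on an aromatic carbon. Among the measured compounds shown here, no measured step touches this same position; the only step measured, a number 7 percentage points lower from compound 1 to compound 2 (within the scatter), exchanged the whole group on that amine nitrogen and stayed within the scatter. A change no larger than the scatter is therefore expected for compound 3, a number 3 percentage points higher from compound 2 to compound 3 (within the scatter). Compound 3 is estimated at 10%, with a range from 0% to 25%.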

Compound 3, a percentage reported as inhibition, in the whole organism at one dose (the size of the read-out at that dose, not a potency): 8%
Compound 3: middle estimate off by 2 percentage points, on the high side; the measured number falls inside the stated range.
By their numbers in this assay, from the lowest: compounds 2, 3 and 1 (each within the scatter of the next).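

In this assay, methoxy in place of chloro on an aromatic carbon, meta to a large group, gives a number 1 percentage points higher from compound 2 to compound 3 (within the scatter), even though methoxy brings one hydrogen-bond acceptor and chloro none. Exchanging the whole group on the ring nitrogen, 3-methoxyphenyl in place of 4-fluorophenyl, gives a number 6 percentage points lower from compound 1 to compound 3 (within the scatter), so all three compounds lie within the scatter of one another at this one dose. Nothing available explains this result.

As far as these compounds go, whether any group on this aromatic ring can move the effect beyond the scatter remains open. An amine or a carboxylic acid at this position could test that.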